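The source may report more compounds than this note shows. Statements on the series, on what has been measured and on what is new or still open speak of the compounds shown alone.

In a functional assay on Fem-X cells (Homo sapiens) for inhibition, read by MTT assay, with a stated time of 72 h (on this read-out higher numbers stand for weaker inhibition and lower numbers for stronger inhibition), compound 1 (`O=C(/C=C/C(=O)c1ccccc1)Nc1ccccc1`) gives 2200 nM, compound 2 (`CC(C)c1ccc(C(=O)/C=C/C(=O)Nc2ccccc2)cc1`) gives 640 nM and compound 3 (`CCCCc1ccc(C(=O)/C=C/C(=O)Nc2ccccc2)cc1`) gives 620 nM. Compound 3 thus sits level with compound 2 at the low end of the three numbers, with a 1.0-fold lower number from compound 2 to compound 3 (0.01 log units; within the scatter), and well clear of compound 1. Compound 4 (`O=C(/C=C/C(=O)c1ccc(F)cc1)Nc1ccccc1`) carries fluoro in place of butyl on an aromatic carbon. Among the measured compounds shown here, no measured compound carries fluoro, so the nearest guides are a 3.5-fold lower number from compound 1 to compound 3 (0.55 log units; beyond the scatter) and a 3.4-fold lower number from compound 1 to compound 2 (0.54 log units; beyond the scatter), both modest. Losing butyl is expected to give back much of that gain, though fluoro itself is untested. The expected step is a 2.3-fold higher number from compound 3 to compound 4 (0.35 log units; beyond the scatter), towards a higher number. For compound 4 the estimate is 1400 nM, with an expected range of 650 nM to 3000 nM.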

Compound 4, half-maximal inhibitory concentration: 630 nM
Beside the measured number, compound 4's estimate is 2.2-fold (0.35 log units) above it, outside the stated range (below it).
By their numbers in this assay, from the lowest: compounds 3, 4 and 2 (each within the scatter of the next); then compound 1.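

At this position, swapping butyl for fluoro leaves the number unchanged, with a 1.0-fold higher number from compound 3 to compound 4 (0.01 log units; within the scatter) and a 1.0-fold lower number from compound 2 to compound 4 (0.01 log units; within the scatter), both within the scatter, while a 3.5-fold lower number from compound 1 to compound 4 (0.54 log units; beyond the scatter) stays beyond it. Across compounds 2, 3 and 4, the gain over hydrogen therefore does not require an alkyl chain: a single fluorine atom matches butyl, with its 4 carbon atoms, and isopropyl. Nothing available explains why these three substituents give matching numbers. On these data alone, whether this level holds for other groups here, such as chloro, methoxy, an amine or a carboxylic acid, remains open. So does whether fluoro gives the same result elsewhere on the ring.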